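The compounds below may be only part of what the source reports. "The series", "measured", "known", "first", "only" and "open" are said of these compounds alone.

Measured so far in an ADME assay on MDA-MB-231 cells (Homo sapiens) for cytotoxicity, with a stated time of 72 h; on this read-out lower numbers stand for stronger inhibition of growth and higher numbers for weaker inhibition of growth:
compound 1 `NC(=O)CN(CCC(c1ccccc1)c1ccccc1)C(=O)CN(CCC(c1ccccc1)c1ccccc1)C(=O)CNCC1CCCO1` gives 2720 nM
compound 2 `NC(=O)CN(CCC(c1ccccc1)c1ccccc1)C(=O)CNCCC(c1ccccc1)c1ccccc1` gives 3080 nM
compound 3 `O=C(CNCCC(c1ccccc1)c1ccccc1)NCCC(c1ccccc1)c1ccccc1` gives 3460 nM

Compound 3 sits at the high end of these three numbers, yet its gaps to compound 2 and to compound 1 are both within the scatter. Compound 4 `O=C(CN(CCC(c1ccccc1)c1ccccc1)C(=O)CNCC1CCCO1)NCCC(c1ccccc1)c1ccccc1` is not yet measured; it differs from compound 3 by ((((oxolan-2-yl)methyl)amino)methyl)carbonyl in place of hydrogen on an amine nitrogen. The reverse of this change has already been measured: a 1.1-fold higher number from compound 1 to compound 2 (0.05 log units; within the scatter) took the same group off an amine nitrogen and left the number within the scatter. The other step, a 1.1-fold higher number from compound 2 to compound 3 (0.05 log units; within the scatter), also stayed within the scatter. For the measured compounds named here, no step has moved beyond the scatter, so for compound 4 no shift beyond the scatter is expected in this assay, a 1.0-fold lower number from compound 3 to compound 4 (0.02 log units; within the scatter). Compound 4 is estimated at 3300 nM, with a range of 1800 nM to 6200 nM.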

Compound 4, concentration for 50% growth inhibition: 1060 nM
For compound 4 the middle estimate is 3.1-fold (0.49 log units) above the measured one; measured number below the stated range.
By their numbers in this assay, from the lowest: compound 4; then compounds 1, 2 and 3 (each within the scatter of the next).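

In this assay, ((((oxolan-2-yl)methyl)amino)methyl)carbonyl in place of hydrogen on an amine nitrogen now gives a step beyond the scatter, a 3.3-fold lower number from compound 3 to compound 4 (0.51 log units; beyond the scatter), so the effect of this change depends on the core that carries it: the same change on two cores in this assay, a 1.1-fold higher number (0.05 log units; within the scatter) from compound 1 to compound 2 and a 3.3-fold higher number (0.51 log units; beyond the scatter) from compound 4 to compound 3, 2.9-fold (0.46 log units) apart, beyond the scatter of two such steps. Hydrogen in place of carbamoylmethyl on an amide-type nitrogen also depends on the core, with a 2.6-fold lower number from compound 1 to compound 4 (0.41 log units; beyond the scatter) when the oxolan-2-yl group is present: the same change on two cores in this assay, a 1.1-fold higher number (0.05 log units; within the scatter) from compound 2 to compound 3 and a 2.6-fold lower number (0.41 log units; beyond the scatter) from compound 1 to compound 4, 2.9-fold (0.46 log units) apart, beyond the scatter of two such steps.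

Still open, from the compounds shown here alone, is whether the oxolan-2-yl ring itself matters or whether an open-chain ether or a simple amine would serve equally at that end of the group. Also open, going by these compounds, is how a carboxylic acid in place of carbamoylmethyl would behave on the amide-type nitrogen.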